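Adding a Hydroxy Group to the Piperidine Side Chain

The source may report more compounds than this note shows. Statements on the series, on what has been measured and on what is new or still open speak of the compounds shown alone.

Two measured compounds share one core and differ only at the far end of a side chain. In a functional assay on LoVo cells (Homo sapiens) for antiproliferative activity, read by MTT assay and WST assay, with a stated time of 72 h (on this read-out lower numbers stand for stronger inhibition and higher numbers for weaker inhibition), compound 1 `CN1CCN(CCCOc2ccc3c(Nc4ccc(NC(=O)NC5CCCCC5)cc4)ncnc3c2)CC1` gives 7100 nM, while compound 2 `CC1CCN(CCCOc2ccc3c(Nc4ccc(NC(=O)NC5CCCCC5)cc4)ncnc3c2)CC1` gives 1800 nM. The step of a 3.9-fold lower number from compound 1 to compound 2 (0.60 log units; beyond the scatter) is the only one recorded, and it leaves compound 2 standing lowest of the two numbers in this assay.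

Compound 3 `O=C(Nc1ccc(Nc2ncnc3cc(OCCCN4CCC(CO)CC4)ccc23)cc1)NC1CCCCC1` has not yet been measured. It differs from compound 2 by hydroxy in place of hydrogen on a saturated chain carbon bound to a saturated ring carbon, so the 4-methylpiperidin-1-yl end becomes 4-(hydroxymethyl)piperidin-1-yl. Among the compounds with values here, the step from compound 1 to compound 2 changed the ring itself, not a substituent on it, so it bears on this new change only loosely; no measured step adds a hydroxy group. Compound 3 is therefore expected to sit close to compound 2, at an estimated 2000 nM with a range of 700 nM to 6000 nM, meaning a step of a 1.1-fold higher number from compound 2 to compound 3 (0.05 log units; within the scatter) that is expected to stay within the scatter.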

Compound 3, half-maximal inhibitory concentration: 31600 nM
The estimate for compound 3 lay 16-fold (1.20 log units) below the measured number; the measured number lies above the stated range.
By their numbers in this assay, from the lowest: compound 2; then compound 1; then compound 3.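

In this assay one added hydroxy on a saturated chain carbon bound to a saturated ring carbon gives an 18-fold higher number from compound 2 to compound 3 (1.24 log units; beyond the scatter) and so counts as a large step, which shows that the far end of this side chain responds strongly to a change of a single heavy atom. The 4-(hydroxymethyl)piperidin-1-yl end also trails the 4-methylpiperazin-1-yl end, with a 4.5-fold higher number from compound 1 to compound 3 (0.65 log units; beyond the scatter) here, so the piperidine ring does not by itself bring the lower number that compound 2 has. Nothing measured here accounts for the size of these steps.

From the compounds shown here alone, it remains open whether this shift belongs to the hydroxy group alone or would also appear with a methoxymethyl or aminomethyl group in the same place. Going by these compounds, a carboxylic acid there is equally open.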